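Removing a Methoxy Group from a Hydroxamic Acid Sulfonamide

The source may report more compounds than this note shows. Statements on the series, on what has been measured and on what is new or still open speak of the compounds shown alone.

Of the compounds shown here, three have been tested in a functional assay on MM1.S cells (Homo sapiens) for inhibition, with a stated time of 72 h; on this read-out higher numbers stand for weaker inhibition and lower numbers for stronger inhibition. Compound 1 `CC(C)N(Cc1ccc(C(=O)NO)cc1)S(=O)(=O)c1c(F)c(F)c(F)c(F)c1F` gives 440 nM, compound 3 `CC(C)N(Cc1ccc(C(=O)NO)cc1)C(=O)c1c(F)c(F)c(F)c(F)c1F` gives 12300 nM, and compound 2 `COc1cc(C(=O)NO)ccc1CN(C(C)C)S(=O)(=O)c1cc(F)c(F)c(F)c1F` gives 5750 nM. Among these three numbers compound 2 holds the second highest; its nearest neighbour is compound 3, at a gap beyond the usual scatter, and its furthest is compound 1. Compound 4 `CC(C)N(Cc1ccc(C(=O)NO)cc1)S(=O)(=O)c1cc(F)c(F)c(F)c1F` has not yet been measured. It differs from compound 2 in one place: hydrogen in place of methoxy on an aromatic carbon. Among the compounds with values here, no measured pair shows this exact change. Compound 1 also lacks the methoxy and gives 440 nM, a low number. On that basis a drop beyond the scatter is expected, with a step of a 6.4-fold lower number from compound 2 to compound 4 (0.81 log units; beyond the scatter). Compound 4 is expected near 900 nM, within 300 nM to 3000 nM.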

Compound 4, half-maximal inhibitory concentration: 1380 nM
The estimate for compound 4 lay 1.5-fold (0.19 log units) below the measured number; the range from low to high includes it.
By their numbers in this assay, from the lowest: compound 1; then compound 4; then compound 2; then compound 3.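

In this assay, within the data shown here, hydrogen in place of methoxy gives a 4.2-fold lower number from compound 2 to compound 4 (0.62 log units; beyond the scatter) and so provides the first direct reading of this change at this position. Hydrogen in place of fluoro on an aromatic carbon gives a 3.1-fold higher number from compound 1 to compound 4 (0.50 log units; beyond the scatter) and shows that removing the methoxy alone does not bring the number down to that of compound 1. No measurement available here explains either step.

Still open, as far as these compounds go, is how other groups at the methoxy position, such as an amine or a longer ethoxy chain, would compare with methoxy and hydrogen.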